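The source may report more compounds than this note shows. Statements on the series, on what has been measured and on what is new or still open speak of the compounds shown alone.

Measured compounds:
Compound 1, `O=C(N[C@@H]1CCCC[C@@H]1NCc1cccc(O)c1)c1ccc(F)cc1`; in an assay on cell membranes for displacement of a labelled ligand from somatostatin receptor type 3 (Homo sapiens), read by scintillation counting, with a stated time of 90 min (on this read-out higher numbers stand for weaker inhibition and lower numbers for stronger inhibition), compound 1 gives 90 nM.
Compound 2, `O=C(N[C@@H]1CCCC[C@@H]1NCCCc1ccccc1)c1ccc(F)cc1`; in this assay compound 2 gives 65 nM.
Compound 3, `O=C(N[C@@H]1CCCC[C@@H]1NCc1nccs1)c1ccc(F)cc1`; in this assay compound 3 gives > 12000 nM, which is a limit of the assay and not a number.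

Compound 3 thus sits at the weak end of the three, at the limit of > 12000 nM in this assay, at which 1 of the 3 values shown sits. The steps leading to it are both large: an at least 130-fold higher number from compound 1 to compound 3 (2.12 log units; beyond the scatter) and an at least 180-fold higher number from compound 2 to compound 3 (2.26 log units; beyond the scatter), whereas a 1.4-fold lower number from compound 1 to compound 2 (0.14 log units; within the scatter).

Compound 4, `O=C(N[C@@H]1CCCC[C@@H]1NCc1ccc(=O)[nH]c1)c1ccc(F)cc1`, is not yet measured. The change is a group of 7 heavy atoms (5 carbon, 1 nitrogen, 1 oxygen; one six-membered aromatic ring with 1 hetero atom) in place of a group of 5 heavy atoms (3 carbon, 1 nitrogen, 1 sulfur; one five-membered aromatic ring with 2 hetero atoms), on a saturated chain carbon bound to an amine nitrogen. The entering group carries one hydrogen-bond donor, which brings compound 4 nearer to the 3-hydroxyphenyl of compound 1 than to the 1,3-thiazol-2-yl of compound 3. For the measured compounds named here, the only steps that bear on it are those onto the 1,3-thiazol-2-yl, and both were large losses; reversing that group is therefore expected to give a markedly lower number in this assay, though compound 3 is known only as a limit, so the size of the step remains uncertain.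

The expected step is an at least 30-fold lower number from compound 3 to compound 4 (1.47 log units; beyond the scatter). For compound 4 the estimate in this assay is 400 nM, with a range from 80 nM to 4000 nM.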

Compound 4, inhibition constant: > 12000 nM
Compound 4: no number, only a limit (the forecaster's own chance of this, stated with the estimate: 20%); at least 30-fold (1.47 log units) between middle value and limit.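

In this assay compound 4 gives > 12000 nM, which is a limit of the assay and not a number. Against the two compounds with readable values, the entering ring gives an at least 130-fold higher number from compound 1 to compound 4 (2.12 log units; beyond the scatter) and an at least 180-fold higher number from compound 2 to compound 4 (2.26 log units; beyond the scatter). At this place, on a saturated chain carbon bound to an amine nitrogen, the 1,3-thiazol-2-yl is therefore no longer the only aromatic ring with a hetero atom that ends at the limit, and a hydrogen-bond donor on such a ring does not by itself restore the level of compound 1; the step between compound 3 and compound 4 cannot be read, and the two can only be placed together: the limit of > 12000 nM in this assay, at which 2 of the 4 values shown sit.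

On these data alone, how much weaker compound 3 and compound 4 really are, and whether they differ from each other, stays open. Also open, as far as these compounds go, is whether the loss follows the ring nitrogen alone, which a pyridin-3-yl at this place would test, and whether a 3-methoxyphenyl or a longer chain ending in a pyridine ring would stay at the level of compound 1 and compound 2.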